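Butyl in Place of Nitro on the Aryl Group

The source may report more compounds than this note shows. Statements on the series, on what has been measured and on what is new or still open speak of the compounds shown alone.

For the measured compounds named here, compound 2 `O=C1C2=C(C(=O)c3ncccc31)C1(CS2)NC(=O)N(c2ccc([N+](=O)[O-])cc2)C1=O` gives 350 nM in a functional assay on MCF7 cells (Homo sapiens) for antiproliferative activity, read by MTT assay, with a stated time of 96 h (a higher number here means a weaker inhibitor, a lower number a stronger inhibitor), the lowest of the three numbers measured so far. Compound 3 `O=C1NN(c2ccc([N+](=O)[O-])cc2)C(=O)C2(CSC3=C2C(=O)c2ncccc2C3=O)N1` gives 550 nM, within the scatter of compound 2, while compound 1 `O=C1NNC(=O)C2(CSC3=C2C(=O)c2ncccc2C3=O)N1` gives 1250 nM, beyond it. Going by the values given here, the only single-place step measured, a 2.3-fold lower number from compound 1 to compound 3 (0.36 log units; beyond the scatter), brought the 4-nitrophenyl onto the core. Compound 4 `CCCCc1ccc(N2C(=O)NC3(CSC4=C3C(=O)c3ncccc3C4=O)C2=O)cc1` differs from compound 2 by butyl in place of nitro on an aromatic carbon. Among the compounds with values here, no measured step touches the substituent on that aryl ring, so the step of a 1.6-fold higher number from compound 2 to compound 4 (0.20 log units; within the scatter) is expected to stay close to the scatter, leaning towards a somewhat higher number. In this assay compound 4 is therefore estimated at 550 nM, within 200 nM to 1600 nM.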

Compound 4, half-maximal inhibitory concentration: 70 nM
The estimate for compound 4 lay 7.9-fold (0.90 log units) above the measured number; the whole stated range lies above it.
By their numbers in this assay, from the lowest: compound 4; then compounds 2 and 3 (each within the scatter of the next); then compound 1.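

In this assay, for the compounds shown here, the step of a 5.0-fold lower number from compound 2 to compound 4 (0.70 log units; beyond the scatter) shows that the substituent on this aryl ring, which no earlier step touched, can move the number beyond the scatter. The change from 4-nitrophenyl to 4-butylphenyl, on an aromatic carbon para to a large group, swaps a group with hydrogen-bond acceptors for an all-carbon chain, and the number falls. No measured evidence here accounts for this drop. On these data alone, it remains open whether ethyl, a longer chain such as octyl, or an amine at this place would follow butyl, and whether butyl would give a similar step on the core of compound 3.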